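The compounds below may be only part of what the source reports. "The series", "measured", "known", "first", "only" and "open" are said of these compounds alone.

Compound 1 `COc1ccc(-c2cn(C(=O)Nc3cc(OC)c(OC)c(OC)c3)c(=O)n2-c2cc(OC)c(OC)c(OC)c2)cc1O` has no result to compare in a functional assay on Bel-7402 cells (Homo sapiens) for cytotoxicity, read by MTT assay, with a stated time of 48 h (on this read-out lower numbers stand for stronger inhibition and higher numbers for weaker inhibition), where compound 1 is recorded as "not determined" (no result reported). Compound 2 `COc1cc(-n2c(-c3ccccc3)cn(C(C)=O)c2=O)cc(OC)c1OC` gives > 50000 nM in this assay, and this is a limit, not an exact number. Compound 3 `COc1cc(-n2c(-c3ccc(F)cc3F)cn(C(C)=O)c2=O)cc(OC)c1OC` differs from compound 2 in one place: 2,4-difluorophenyl in place of phenyl on an aromatic carbon, with 2,4-difluorophenyl in place of phenyl on an aromatic carbon. Among the measured compounds shown here, no measured step offers a guide, so only a modest shift towards stronger inhibition is expected, and another limit is possible. The expected size is an at least 1.6-fold lower number from compound 2 to compound 3 (0.22 log units; that floor lies within the scatter). The estimated value for compound 3 is 30000 nM, within an expected range of 6000 nM to 60000 nM.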

Compound 3, half-maximal inhibitory concentration: 36200 nM
For compound 3 the middle estimate is 1.2-fold (0.08 log units) below the measured one, and the stated range covers the measured number.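

In this assay, placing 2,4-difluorophenyl on this aromatic carbon in place of phenyl gives an at least 1.3-fold lower number from compound 2 to compound 3 (0.14 log units; that floor lies within the scatter). Compound 3 is the only compound shown with an exact number, so this position now has a firm reference value, though no clear gain in strength can be claimed from it. The true size of the step stays unknown because compound 2 is recorded only as a limit: the limit of > 50000 nM in this assay, at which 1 of the 3 values shown sits.

The compounds shown leave open what a single fluorine would do on this ring. They also leave open how an amine or a carboxylic acid there would read.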